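A few compounds are considered here, and "the series" means these few. Any claim that something is new, unique, unknown or untested is made for them only; others in the source may bear on it.

Measured in a functional assay on A-375 cells (Homo sapiens) for cytotoxicity, read by CCK-8 assay, with a stated time of 24 h; a higher number here means a weaker inhibitor, a lower number a stronger inhibitor:
- compound 1 `COc1ccccc1Oc1c(N)nc(-c2ccc(C)cc2)nc1OCCO`: 2380 nM
- compound 2 `COc1ccccc1Oc1c(N)nc(-c2cccc(Cl)c2)nc1OCCO`: 30200 nM
- compound 3 `COc1ccccc1Oc1c(N)nc(-c2ccc(Br)cc2)nc1OCCO`: 10300 nM

Compound 3 lies in the middle of these three numbers. Compound 4 `COc1ccccc1Oc1c(N)nc(-c2cccc(I)c2)nc1OCCO` carries 3-iodophenyl in place of 4-bromophenyl on an aromatic carbon. Compound 2, the 3-chlorophenyl analogue, is the closest comparison. The measured step of a 2.9-fold lower number from compound 2 to compound 3 (0.47 log units; beyond the scatter) points to a modest rise on returning to a 3-halophenyl group. The large step of a 13-fold higher number from compound 1 to compound 2 (1.10 log units; beyond the scatter) points the same way, while a 4.3-fold higher number from compound 1 to compound 3 (0.64 log units; beyond the scatter) shows that a 4-substituted ring can also shift the number. A modest rise is therefore expected, a 2.1-fold higher number from compound 3 to compound 4 (0.33 log units; beyond the scatter). The estimate for compound 4 is 22000 nM, with an expected range of 8000 nM to 60000 nM.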

Compound 4, half-maximal inhibitory concentration: 1230 nM
For compound 4 the middle estimate is 18-fold (1.25 log units) above the measured one; the whole stated range lies above it.
By their numbers in this assay, from the lowest: compounds 4 and 1 (each within the scatter of the next); then compound 3; then compound 2.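

In this assay a 3-halophenyl group at this position, para to a 2-methoxyphenoxy group, need not give a high number: iodo in place of chloro gives a 25-fold lower number from compound 2 to compound 4 (1.39 log units; beyond the scatter) and shows that the identity of the halogen counts strongly here. The change from 4-bromophenyl to 3-iodophenyl, with an 8.4-fold lower number from compound 3 to compound 4 (0.92 log units; beyond the scatter) as its step, alters ring position and halogen together, while a 1.9-fold lower number from compound 1 to compound 4 (0.29 log units; within the scatter) leaves the 3-iodophenyl and 4-methylphenyl groups level. Nothing measured here accounts for these steps. Still open, from the compounds shown here alone, is how 3-bromophenyl or 4-iodophenyl would read, which could separate ring position from halogen, and how an amine or a carboxylic acid on this ring would behave.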